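Chlorine for Fluorine on a Cyclopropyl-Bearing Core

A few compounds are considered here, and "the series" means these few. Any claim that something is new, unique, unknown or untested is made for them only; others in the source may bear on it.

Of the compounds shown here, three built on one shared core have been tested in a functional assay on BGC-823 cells (Homo sapiens) for antiproliferative activity, read by MTT assay, with a stated time of 48 h; on this read-out higher numbers stand for weaker inhibition and lower numbers for stronger inhibition. Compound 1, `CCn1cc(-c2ccc(F)cc2)c(=O)c2cc(F)c(N3CCNCC3)cc21`, gives 69600 nM in this assay. Compound 2, `CCn1cc(-c2ccc(Cl)cc2)c(=O)c2cc(F)c(N3CCNCC3)cc21`, gives 14600 nM. Compound 3, `O=c1c(-c2ccc(F)cc2)cn(C2CC2)c2cc(N3CCNCC3)c(F)cc12`, gives 15100 nM, a number that lies within the usual scatter of the value of compound 2.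

Two single changes connect these compounds. From compound 1 to compound 2 the change is chloro in place of fluoro on an aromatic carbon, and it brings a 4.8-fold lower number from compound 1 to compound 2 (0.68 log units; beyond the scatter). From compound 1 to compound 3 the change is cyclopropyl in place of ethyl on an aromatic nitrogen, and it brings a 4.6-fold lower number from compound 1 to compound 3 (0.66 log units; beyond the scatter).

Compound 4, `O=c1c(-c2ccc(Cl)cc2)cn(C2CC2)c2cc(N3CCNCC3)c(F)cc12`, has not yet been measured. Among the compounds with values here, it differs from compound 3 by chloro in place of fluoro on an aromatic carbon, the same change as the one from compound 1 to compound 2, made at the same place. The two cores on which this change is made differ by cyclopropyl in place of ethyl on an aromatic nitrogen.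

Because the step of a 4.8-fold lower number from compound 1 to compound 2 (0.68 log units; beyond the scatter) was seen once on the core of compound 1, a step of similar direction is expected on the core of compound 3, so from compound 3 to compound 4 a step of about a 3.8-fold lower number from compound 3 to compound 4 (0.58 log units; beyond the scatter) is estimated, allowing that a change repeated on a different core need not carry over in full. Compound 4 is therefore expected to give about 4000 nM in this assay, most likely between 1500 nM and 12000 nM.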

Compound 4, half-maximal inhibitory concentration in the BGC-823 assay: 12900 nM
Estimate against measurement, compound 4: 3.2-fold (0.51 log units) below, and the stated range ends below it.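

In the BGC-823 assay, chloro in place of fluoro on the core of compound 3 gives a 1.2-fold lower number from compound 3 to compound 4 (0.07 log units; within the scatter), so the drop seen on the core of compound 1 did not carry over to this second core: the same change on two cores in the BGC-823 assay, a 4.8-fold lower number (0.68 log units; beyond the scatter) from compound 1 to compound 2 and a 1.2-fold lower number (0.07 log units; within the scatter) from compound 3 to compound 4, 4.1-fold (0.61 log units) apart, beyond the scatter of two such steps

Read along the other edge of the same square, cyclopropyl in place of ethyl gives a 1.1-fold lower number from compound 2 to compound 4 (0.05 log units; within the scatter), so in these four compounds either change alone lowers the number from that of compound 1, but making both brings no further readable drop: the same change on two cores in the BGC-823 assay, a 4.6-fold lower number (0.66 log units; beyond the scatter) from compound 1 to compound 3 and a 1.1-fold lower number (0.05 log units; within the scatter) from compound 2 to compound 4, 4.1-fold (0.61 log units) apart, beyond the scatter of two such steps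

This shows that in this series the size of the step depends on the core that carries it, yet it rests on a single pair of cores and does not show why the two changes fail to add up, nor how the change would behave on any other core.

In a physicochemical assay for solubility, at pH 7.9 (a lower number here means a less soluble compound, a higher number a more soluble compound), compound 3 gives > 400000 nM, which is a limit of the assay and not a number. In the physicochemical assay, compound 4 gives > 400000 nM, which is likewise a limit of the assay and not a number. The step between compound 3 and compound 4 cannot be read, so the swap's bearing on this read-out stays open: the limit of > 400000 nM in the physicochemical assay, at which 2 of the 2 values shown sit.

Also open, going by these compounds, is whether another group on the phenyl ring, such as bromo or methoxy, or a longer chain such as propyl on the ring nitrogen, would take the number in the BGC-823 assay lower than these four compounds reach.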